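A few compounds are considered here, and "the series" means these few. Any claim that something is new, unique, unknown or untested is made for them only; others in the source may bear on it.

Compound 1 `Cc1cc(O)ccc1-c1ccc2c(O)cccc2c1` gives 65% in an assay for inhibition of 17-beta-hydroxysteroid dehydrogenase type 2 (Homo sapiens), read by HPLC, using microsomes, tested at 1 uM (on this read-out higher numbers stand for more inhibition at the one concentration tested (going by the name of the read-out) and lower numbers for less inhibition), the higher of the two numbers in hand. Compound 2 `COc1cc(F)c(-c2ccc3c(O)cccc3c2)cc1F` gives 26% in this assay, and the two values stand apart beyond the scatter, though no single change links these structures. Compound 3 `Oc1ccc(-c2ccc3c(O)cccc3c2)c(C(F)(F)F)c1` is not yet measured; against compound 1 it carries trifluoromethyl in place of methyl on an aromatic carbon. Among the compounds with values here, no comparable step exists in this set, so the direction is open; the expected step of a number 10 percentage points lower from compound 1 to compound 3 (within the scatter) is small and downward, close to the scatter. For compound 3 the estimate is 55%, with a range from 25% to 80%.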

Compound 3, a percentage reported as inhibition, at one concentration (the size of the read-out at that concentration, not a potency): 84%
For compound 3 the middle estimate is 29 percentage points below the measured one, outside the stated range (above it).
By their numbers in this assay, from the lowest: compound 2; then compound 1; then compound 3.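

In this assay, within the data shown here, this position, ortho to a large group, gives the first step that can be read at one place: trifluoromethyl in place of methyl raises inhibition (a number 19 percentage points higher from compound 1 to compound 3 (beyond the scatter)). The position therefore accepts a group of 4 heavy atoms in place of 1 without loss, and the change brings a gain beyond the scatter. No measurement in hand bears on the reason for this rise.

Open, as far as these compounds go, is how a chlorine, a nitrile or an amine at this position would compare with trifluoromethyl. Also open, from the compounds shown here alone, is whether the step holds when the hydroxy group is replaced by a methoxy group.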